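Cytotoxicity notes on a diaryl ether aniline series

The source may report more compounds than this note shows. Statements on the series, on what has been measured and on what is new or still open speak of the compounds shown alone.

Measured compounds:
- compound 1, `Cc1ccc(Nc2cc(Oc3c(C)cc(Br)cc3C)c([N+](=O)[O-])cc2[N+](=O)[O-])cc1`: 53000 nM
- compound 2, `Cc1cc(C)c(Oc2ccc(N)c(Nc3ccc(C#N)cc3)c2)c(C)c1`: 51000 nM
- compound 3, `Cc1cc(C)c(Oc2cc(Nc3ccc(C#N)cc3)c([N+](=O)[O-])cc2[N+](=O)[O-])c(C)c1`: > 59800 nM

In an ADME assay on H9 cells (Homo sapiens) for cytotoxicity, read by XTT assay, with a stated time of 6 days (on this read-out higher numbers stand for lower toxicity in this test and lower numbers for higher toxicity in this test), compound 1 gives 53000 nM. Compound 2 gives 51000 nM in this assay, and the two values lie within the scatter of each other, so no order can be drawn between them. For compound 3 the result in this assay is a limit rather than a number, > 59800 nM; the limit is recorded as the limit of > 59800 nM in this assay, at which 1 of the 3 values shown sits. Compound 1 thus holds the highest of the two numbers given, with compound 2 close beside it.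

The unmeasured compound 4, `COc1ccc(Nc2cc(Oc3c(C)cc(Br)cc3C)c([N+](=O)[O-])cc2[N+](=O)[O-])cc1`, differs from compound 1 in one place: methoxy in place of methyl on an aromatic carbon. Within the data shown here, no step between two measured compounds is available to gauge this change, and nothing among the measured compounds marks it as consequential. A step within the scatter is expected, in no particular direction. Compound 4 is estimated at 50000 nM, in the range 25000 nM to 100000 nM, which as a step from compound 1 reads a 1.1-fold lower number from compound 1 to compound 4 (0.03 log units; within the scatter), an expected change no larger than the scatter.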

Compound 4, half-maximal cytotoxic concentration: 51200 nM
Beside the measured number, compound 4's estimate is 1.0-fold (0.01 log units) below it; the measured number falls inside the stated range.
By their numbers in this assay, from the lowest: compounds 2, 4 and 1 (each within the scatter of the next). At a limit, above all of these: compound 3.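

Among these compounds, the first change in one place, 4-methylphenyl to 4-methoxyphenyl, reads in this assay as a 1.0-fold lower number from compound 1 to compound 4 (0.02 log units; within the scatter) and so gives no sign of a change in this read-out. At this position, para to a large group, the entering oxygen and its hydrogen-bond acceptor therefore leave the result within the scatter, though this rests on a single pair of compounds. No measured property on hand bears on this result.

On these data alone, whether this position stays as undemanding with an amine, a carboxylic acid or a longer alkoxy chain remains open. Among the compounds shown here, also open is whether methoxy in place of methyl would read the same on a compound other than compound 1, since the series offers only this one pair for the change.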